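The source may report more compounds than this note shows. Statements on the series, on what has been measured and on what is new or still open speak of the compounds shown alone.

Working notes on the amide series. Compound 3 `COc1ccc2nc(C)cc(OCC(=O)Nc3ccc(Cl)cc3Cl)c2c1` gives 20500 nM in a physicochemical assay for solubility, in phosphate buffer, measured as kinetic solubility, with a stated time of 1 h, at pH 7.4 (a lower number here means a less soluble compound, a higher number a more soluble compound), which places it second highest of the three numbers measured. Compound 1 `COc1ccc2nc(C)cc(OCC(=O)NCc3cc(C)cc(C)c3)c2c1` gives 92000 nM in this assay, and compound 2 `COc1ccc2nc(C)cc(OCC(=O)Nc3cc(F)cc(F)c3)c2c1` gives 13000 nM. For the measured compounds named here, the move from the benzyl-type amide to the anilide-type amides is the only change that clearly registers: a 4.5-fold lower number from compound 1 to compound 3 (0.65 log units; beyond the scatter) and a 7.1-fold lower number from compound 1 to compound 2 (0.85 log units; beyond the scatter). Between the two anilides the difference is a 1.6-fold higher number from compound 2 to compound 3 (0.20 log units; within the scatter), so no order can be read between compound 2 and compound 3.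

Compound 4 `COc1ccc2nc(C)cc(OCC(=O)Nc3nccs3)c2c1` awaits measurement. Its change from compound 3: 1,3-thiazol-2-yl in place of 2,4-dichlorophenyl on an amide-type nitrogen. Going by the values given here, no measured step bears directly on this replacement; the one step that alters the ring substituents on the same kind of nitrogen, from compound 2 to compound 3, stays within the scatter, and the steps beyond the scatter concern the benzyl-to-phenyl change, which compound 4 keeps unchanged. The entering group is smaller, with fewer heavy atoms and two hydrogen-bond acceptors where the leaving group had none, so a modest upward step is expected, but with wide uncertainty. Compound 4 is expected at 45000 nM, with a range of 15000 nM to 140000 nM. That estimate corresponds to an expected step of a 2.2-fold higher number from compound 3 to compound 4 (0.34 log units; beyond the scatter).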

Compound 4, solubility: 54000 nM
The estimate for compound 4 lay 1.2-fold (0.08 log units) below the measured number; the range from low to high includes it.
By their numbers in this assay, from the lowest: compounds 2 and 3 (each within the scatter of the next); then compounds 4 and 1 (each within the scatter of the next).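

For the compounds shown here, on the amide-type nitrogen, 1,3-thiazol-2-yl gives the first step among the compounds with a ring on that nitrogen that lies beyond the scatter in this assay, with a 2.6-fold higher number from compound 3 to compound 4 (0.42 log units; beyond the scatter) and a 4.2-fold higher number from compound 2 to compound 4 (0.62 log units; beyond the scatter), whereas the step between the two halogenated phenyl groups stayed within it. The earlier split between the 3,5-dimethylbenzyl amide and the phenyl amides does not extend to this ring, with a 1.7-fold lower number from compound 1 to compound 4 (0.23 log units; within the scatter) leaving compound 4 and compound 1 unresolved in this assay, so compound 4 is the exception to that split. No measurement on hand explains these steps.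

The leaving and entering groups differ at once in ring size, heavy atoms, halogens and hydrogen-bond acceptors, so the compounds shown do not assign the steps to any one of these features. On these data alone, whether the result is particular to 1,3-thiazol-2-yl remains open, and unsubstituted phenyl, pyridin-2-yl or 1,3-thiazol-2-ylmethyl on the same nitrogen would test it in this assay on the shared core.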